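Removing the chloro from compound 2

This account rests on a few compounds, and the source may have more. Where it says the series, first, only, none or still open, it means among the compounds named here.

Compound 1, `O=C(CCSc1nnc(-c2ccncc2)s1)Nc1ccc(Cl)cc1`: 8210 nM
Compound 2, `CC(CSc1nnc(-c2ccncc2)s1)C(=O)Nc1ccc(Cl)cc1`: > 50000 nM
Compound 3, `O=C(CSc1nnc(-c2ccncc2)s1)Nc1ccc(Cl)cc1Cl`: "not determined" (no result reported)

In an ADME assay on BHK-21 cells (Mesocricetus auratus) for cytotoxicity, with a stated time of 3 days (a lower number here means that less compound is tolerated, a higher number that more compound is tolerated), compound 1 gives 8210 nM. For compound 2 the entry > 50000 nM is a limit of the assay and not a number. For compound 3 the entry reads "not determined" (no result reported), so no value is available. Compound 2 thus stands at the top end of what was measured, as the limit of > 50000 nM in this assay, at which 1 of the 3 values shown sits, shows, with one further entry lacking any number.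

Going by the values given here, the only measured step is an at least 6.0-fold higher number from compound 1 to compound 2 (0.78 log units; beyond the scatter), which changes the chain and not the aromatic ring. Compound 4, `CC(CSc1nnc(-c2ccncc2)s1)C(=O)Nc1ccccc1`, differs from compound 2 in another place: hydrogen in place of chloro on an aromatic carbon. Among the compounds with values here, no measured step bears directly on this change, and the one step known runs away from the measurable range. Compound 2 is expected to give way to a step that the limit leaves unreadable from compound 2 to compound 4, no change beyond the scatter. Compound 4 is therefore expected at 60000 nM, with a range from 20000 nM to 180000 nM, most likely again reported only as a limit.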

Compound 4, half-maximal cytotoxic concentration: > 50000 nM
Compound 4: only a limit was reported; the forecaster's own chance of this, stated with the estimate: 75%; the middle value lies beyond the limit too.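

In this assay, going by these compounds alone, compound 2 and compound 4 both give only a limit and not a number, so no step between them can be read: the limit of > 50000 nM in this assay, at which 2 of the 4 values shown sit.

The compounds shown leave open whether hydrogen in place of chloro on an aromatic carbon changes the result in this assay at all.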